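This account rests on a few compounds, and the source may have more. Where it says the series, first, only, none or still open, it means among the compounds named here.

Of the compounds shown here, three with a shared core have been measured in a physicochemical assay for lipophilicity, read by HPLC; on this read-out lower numbers stand for lower lipophilicity and higher numbers for higher lipophilicity. Compound 1 `CNCc1cc(N)c(Nc2ccc(C#N)cc2)cc1Oc1c(C)cc(C#N)cc1C` gives 1.86, compound 2 `COCc1cc(N)c(Nc2ccc(C#N)cc2)cc1Oc1c(C)cc(C#N)cc1C` gives 3.84, and compound 3 `CC(=O)OCc1cc(N)c(Nc2ccc(C#N)cc2)cc1Oc1c(C)cc(C#N)cc1C` gives 4.4, the highest of the three. Compound 4 `CC(=O)OCc1cc(N)c(Nc2ccc(C#N)cc2)cc1Oc1c(C)cc(CCC#N)cc1C` differs from compound 3 in one place: 2-cyanoethyl in place of cyano on an aromatic carbon. In words, it carries 2-cyanoethyl in place of cyano on an aromatic carbon.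

Among the measured compounds shown here, no measured step touches that carbon, so the evidence is indirect. Methoxy in place of methylamino gave a number 1.98 log units higher from compound 1 to compound 2 (beyond the scatter), acetoxy in its place gave a number 2.54 log units higher from compound 1 to compound 3 (beyond the scatter), and acetyl in place of methyl on the oxygen gave a number 0.56 log units higher from compound 2 to compound 3 (beyond the scatter). The first two steps remove methylamino and this change does not, which leaves the third, modest step as the better guide to size.

The nitrile stays and the chain grows longer, and a modest rise in this assay is expected, with an estimated a number 0.40 log units higher from compound 3 to compound 4 (beyond the scatter). Compound 4 is estimated at 4.8, with an expected range from 4.4 to 5.3.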

Compound 4, partition coefficient: 2.84
The estimate for compound 4 lay 1.96 log units above the measured number; the measured number lies below the stated range.
By their numbers in this assay, from the lowest: compound 1; then compound 4; then compound 2; then compound 3.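

The aromatic carbon meta to two methyl groups proves sensitive: in this assay, putting 2-cyanoethyl in place of cyano gives a number 1.56 log units lower from compound 3 to compound 4 (beyond the scatter) even though the entering group has more heavy atoms and the same count of hydrogen-bond donors and acceptors. Among the compounds shown here, the earlier steps all changed the group on the saturated chain carbon, so this is the first sign that this aromatic carbon matters too, and that lengthening the group there with the nitrile kept can lower the number rather than raise it. No measurement shown gives a reason for the fall.

On these data alone, how a propyl group, a cyanomethyl group or a carboxylic acid on this carbon would read stays open, which leaves the part played by the added chain apart from its nitrile unsettled. Also open, as far as these compounds go, is whether the same change acts alike on compound 1 or compound 2.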